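Trading a Trifluoromethyl Aryl Amide for a Methoxy Aryl Amide

The source may report more compounds than this note shows. Statements on the series, on what has been measured and on what is new or still open speak of the compounds shown alone.

Three amides built on one shared core have been measured in a functional assay on MCF7 cells (Homo sapiens) for antiproliferative activity, read by CCK-8 assay, with a stated time of 72 h; on this read-out higher numbers stand for weaker inhibition and lower numbers for stronger inhibition. Compound 1 `O=C(Nc1cccc(-c2oc3cc(-c4ccc(F)cc4)ccc3c(=O)c2O)c1)c1ccccc1F` gives 7570 nM, compound 2 `Cc1ccc(C(=O)Nc2cccc(-c3oc4cc(-c5ccc(F)cc5)ccc4c(=O)c3O)c2)cc1` gives 2400 nM, and compound 3 `O=C(Nc1cccc(-c2oc3cc(-c4ccc(F)cc4)ccc3c(=O)c2O)c1)c1ccc(C(F)(F)F)cc1` gives 32600 nM. Compound 3 thus stands at the highest number of the three: the step from compound 1 to compound 3 is a 4.3-fold higher number from compound 1 to compound 3 (0.63 log units; beyond the scatter), and the step from compound 2 to compound 3 is a 14-fold higher number from compound 2 to compound 3 (1.13 log units; beyond the scatter), while the step from compound 1 to compound 2 is a 3.2-fold lower number from compound 1 to compound 2 (0.50 log units; beyond the scatter).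

Compound 4 `COc1cccc(C(=O)Nc2cccc(-c3oc4cc(-c5ccc(F)cc5)ccc4c(=O)c3O)c2)c1` differs from compound 3 in one place: 3-methoxyphenyl in place of 4-(trifluoromethyl)phenyl on a carbonyl carbon. For the measured compounds named here, no measured pair carries a 3-methoxyphenyl, so the bearing of the earlier steps is indirect. What they do show is that the 4-(trifluoromethyl)phenyl amide of compound 3 sits well above both other aryl amides, as seen in the step from compound 2 to compound 3 of a 14-fold higher number from compound 2 to compound 3 (1.13 log units; beyond the scatter) and from compound 1 to compound 3 of a 4.3-fold higher number from compound 1 to compound 3 (0.63 log units; beyond the scatter). Removing that group in favour of a 3-methoxyphenyl is therefore expected to bring the number back down toward the range of compounds 1 and 2, with the step from compound 3 to compound 4 estimated at a 6.5-fold lower number from compound 3 to compound 4 (0.81 log units; beyond the scatter). Compound 4 is accordingly expected to give about 5000 nM in this assay, within a range from 1500 nM to 16000 nM.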

Compound 4, half-maximal inhibitory concentration: 15300 nM
Beside the measured number, compound 4's estimate is 3.1-fold (0.49 log units) below it, within the range that was stated.
By their numbers in this assay, from the lowest: compound 2; then compound 1; then compound 4; then compound 3.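

In this assay, replacing the 4-(trifluoromethyl)phenyl with a 3-methoxyphenyl on the carbonyl carbon lowers the number only modestly (a 2.1-fold lower number from compound 3 to compound 4 (0.33 log units; beyond the scatter)), so removing the trifluoromethyl group does not by itself bring the amide back to the level of the two best-placed compounds. Compound 4 still stands above both other aryl amides (a 2.0-fold higher number from compound 1 to compound 4 (0.31 log units; beyond the scatter); a 6.4-fold higher number from compound 2 to compound 4 (0.80 log units; beyond the scatter)), and the gap to the 4-methylphenyl amide of compound 2 is the wider of the two, which shows that a high number at this position is not confined to the trifluoromethyl-bearing compound 3, since compound 4 contains no fluorine in this group. Nothing available here explains why these aryl amides differ as they do.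

The step from the 4-methylphenyl to the 3-methoxyphenyl changes both the group and where it sits on the ring, so the two contributions cannot be separated among these four compounds. A 4-methoxyphenyl or a 3-methylphenyl amide would divide them, while an unsubstituted phenyl amide would give a reference for every substituent seen so far.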